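This account rests on a few compounds, and the source may have more. Where it says the series, first, only, none or still open, it means among the compounds named here.

In a functional assay on L02 cells (Homo sapiens) for inhibition, read by Griess assay, with stated times of 1 h and 24 h (on this read-out higher numbers stand for weaker inhibition and lower numbers for stronger inhibition), compound 2 (`COc1cc(/C=C/c2nc(NC3CC3)c3sccc3n2)cc(OC)c1OC`) reaches only the limit of the assay, > 1000000 nM. Compound 1 (`CCCc1nn(C)c2c(NC3CC3)nc(/C=C/c3ccc[n+]([O-])c3)nc12`), built on a different core, gives 580000 nM in this assay. Compound 3 (`COc1cc(/C=C/c2nc(Nc3ccc(C(C)C)cc3)c3sccc3n2)cc(OC)c1OC`) differs from compound 2 in one place: 4-isopropylphenyl in place of cyclopropyl on a nitrogen on an aromatic ring. Within the data shown here, no measured pair shows this change, so neither its size nor its direction in this assay can be read from the data. The expected step from an at least 2.0-fold lower number from compound 2 to compound 3 (0.30 log units; that floor lies within the scatter) is therefore a cautious guess toward a weak but measurable value. For compound 3 the estimate is 500000 nM, with a range from 100000 nM to 2000000 nM.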

Compound 3, half-maximal inhibitory concentration: 370000 nM
Beside the measured number, compound 3's estimate is 1.4-fold (0.13 log units) above it; low and high end bracket the measured number.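

Placing 4-isopropylphenyl in place of cyclopropyl on this nitrogen gives the first readable change at this position: in this assay it gives an at least 2.7-fold lower number from compound 2 to compound 3 (0.43 log units; beyond the scatter). A change in this one place is thus enough to bring the number within the measurable range. The size of the step is only a floor, since one end of it is a limit and not a number: the limit of > 1000000 nM in this assay, at which 1 of the 3 values shown sits.

Whether the aromatic ring or the isopropyl on it accounts for the step stays open. So does what a plain phenyl, a longer alkyl chain or a carboxylic acid-bearing phenyl on this nitrogen would give.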